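A few compounds are considered here, and "the series" means these few. Any claim that something is new, unique, unknown or untested is made for them only; others in the source may bear on it.

Working notes on the series in a functional assay on HT-29 cells (Homo sapiens) for cytotoxicity, read by sulforhodamine B assay, with a stated time of 2 days, tested at 100 uM; a higher number here means more inhibition at the concentration tested (going by the name of the read-out), a lower number less inhibition.

Compound 1, `COc1cccc(-c2nc3c(-c4cccc(Cl)c4)n[nH]c3c(=O)n2NC(=O)c2ccccc2)c1`, gives 91% in this assay. Among the measured compounds shown here, compound 2, `O=C(Nn1c(-c2cccc([N+](=O)[O-])c2)nc2c(-c3ccco3)n[nH]c2c1=O)c1ccccc1`, gives 21.2% in this assay, the lowest of the two numbers measured so far; the only neighbour on the numbers is compound 1, which stands higher by a gap well beyond the usual scatter. The two measured compounds differ in more than one place, so the numbers alone show that the pair spans a wide range, without assigning the gap to any single change.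

The next compound, compound 3, `COc1cccc(-c2nc3c(-c4ccco4)n[nH]c3c(=O)n2NC(=O)c2ccccc2)c1`, is reached from compound 2 by one change: methoxy in place of nitro on an aromatic carbon. Compound 3 thus carries the same 3-methoxyphenyl as compound 1 while keeping the furan ring of compound 2. For the measured compounds named here, no measured pair shows this change on its own, so the direction of the step is not known from the data. Still, an upward step in this assay is expected, a number 33.8 percentage points higher from compound 2 to compound 3 (beyond the scatter), beyond the scatter, because compound 1 with the same 3-methoxyphenyl gives 91% in this assay. Compound 3 is estimated at 55% in this assay, within a range from 25% to 85%.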

Compound 3, a percentage reported as inhibition, at one concentration (the size of the read-out at that concentration, not a potency): 49.8%
For compound 3 the middle estimate is 5.2 percentage points above the measured one, and the stated range covers the measured number.
By their numbers in this assay, from the lowest: compound 2; then compound 3; then compound 1.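

With furan-2-yl held constant, the change from 3-nitrophenyl to 3-methoxyphenyl in this assay gives a number 28.6 percentage points higher from compound 2 to compound 3 (beyond the scatter), so methoxy in place of nitro on this aromatic carbon now has a measured direction and size. With 3-methoxyphenyl held constant, furan-2-yl in place of 3-chlorophenyl gives a number 41.2 percentage points lower from compound 1 to compound 3 (beyond the scatter), which shows that the second place also moves the number on its own, with 3-chlorophenyl the higher of the two groups compared there. Nothing at hand explains either step.

The compounds shown leave open whether methoxy in place of nitro gives a step of similar size and direction when 3-chlorophenyl replaces furan-2-yl, since this change is seen only with furan-2-yl. They also leave open how an amine or a carboxylic acid on the same aromatic carbon would read in this assay, and whether a longer chain such as ethoxy would follow methoxy.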